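The source may hold more compounds than are shown below. What is called first, only, known or untested is meant among the compounds shown, and "the series" means these compounds.

Measured so far in the antiproliferative series:

compound 1, `COCC(C)(C)C#Cc1c(Cl)c2c(Cl)cc(C(N)=O)nc2n1[C@H]1CCCNC1` — 219 nM
compound 2, `CC(O)C#Cc1c(Cl)c2c(Cl)cc(C(N)=O)nc2n1[C@H]1CCCNC1` — 147 nM
compound 3, `NC(=O)c1cc(Cl)c2c(Cl)c(C#CC3COCCO3)n([C@H]3CCCNC3)c2n1` — 77 nM; 203 nM (2 entries)

In a functional assay on KG-1 cells (Homo sapiens) for antiproliferative activity (a lower number here means that less compound is needed, a higher number that more compound is needed for the effect), compound 2 holds the lowest of the two single numbers. Its nearest neighbour is compound 1, and the change a 1.5-fold lower number from compound 1 to compound 2 (0.17 log units; within the scatter) is within the scatter. Compound 3 has no single number; its repeated readings (the several entries of compound 3 in this assay, 77 nM; 203 nM (2 entries)) spread over a range that itself illustrates the scatter of this assay.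

Compound 4, `NC(=O)c1cc(Cl)c2c(Cl)c(C#CCN3CCCC3=O)n([C@H]3CCCNC3)c2n1`, has not yet been measured in this assay. It differs from compound 2 in one place: (2-oxopyrrolidin-1-yl)methyl in place of 1-hydroxyethyl on a triple-bonded carbon. Among the compounds with values here, the only measured step that bears on this position is the one from compound 1 to compound 2, a swap of the group on the triple-bonded carbon, and that step stayed within the scatter. On this evidence a change at this position is expected to move the number little, with no direction beyond the scatter to be predicted; the estimate for compound 4 is therefore placed close to compound 2, with a wide range.

Compound 4 is expected to give 170 nM, between 60 nM and 500 nM.

The estimated step of a 1.2-fold higher number from compound 2 to compound 4 (0.06 log units; within the scatter) is expected to lie within the scatter.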

Compound 4, half-maximal effective concentration: 178 nM
The estimate for compound 4 lay 1.0-fold (0.02 log units) below the measured number; the measured number falls inside the stated range.
By their numbers in this assay, from the lowest: compounds 2, 4 and 1 (each within the scatter of the next).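

In this assay, the triple-bonded carbon also tolerates a group with a ring: (2-oxopyrrolidin-1-yl)methyl, with a five-membered non-aromatic ring and no hydrogen-bond donor, replaces 1-hydroxyethyl, which has one, and the result is a 1.2-fold higher number from compound 2 to compound 4 (0.08 log units; within the scatter). Against 1-(methoxymethyl)-1-methylethyl the picture is the same, with a 1.2-fold lower number from compound 1 to compound 4 (0.09 log units; within the scatter), so the three groups on this carbon in compound 1, compound 2 and compound 4 give numbers within the scatter of one another. Steps of this size cannot be told apart from the spread of repeated readings on a single compound: the several entries of compound 3 in this assay, 77 nM; 203 nM (2 entries)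

The compounds shown leave open whether an amine, a carboxylic acid or a phenyl ring on this carbon would move the number beyond the scatter. They also leave open whether a longer chain would hold it there.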